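A longer chain end on compound 3

This account rests on a few compounds, and the source may have more. Where it says the series, first, only, none or still open, it means among the compounds named here.

Compound 1 `O=C(CCCCCCOc1ccc(-c2nc3ccc(-c4nc5ccccc5[nH]4)cc3[nH]2)cc1)NO` gives 510 nM
Compound 2 `O=C(CCCCCCCOc1cccc(-c2nc3ccc(-c4nc5ccccc5[nH]4)cc3[nH]2)c1)NO` gives 2900 nM
Compound 3 `O=C(CCCCCCOc1cccc(-c2nc3ccccc3[nH]2)c1)NO` gives 290 nM

In a functional assay on K562 cells (Homo sapiens) for inhibition, read by MTT assay, with a stated time of 48 h (on this read-out lower numbers stand for stronger inhibition and higher numbers for weaker inhibition), compound 3 at 290 nM sits within the scatter of compound 1 and beyond the scatter of compound 2, whose number is higher. Compound 4 `O=C(CCCCCCCOc1cccc(-c2nc3ccccc3[nH]2)c1)NO` has (hydroxycarbamoyl)methyl in place of hydroxycarbamoyl on a saturated chain carbon, six bonds along the chain from an oxygen on an aromatic ring. Within the data shown here, no measured pair shows this change alone. Compound 1 and compound 2 differ in more than one place. The estimated 1.4-fold higher number from compound 3 to compound 4 (0.14 log units; within the scatter) is a small rise in the number in this assay and stays within the scatter. For compound 4 the estimated value is 400 nM with an expected range from 130 nM to 1300 nM in this measurement.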

Compound 4, half-maximal inhibitory concentration: 990 nM
Compound 4: the middle estimate sits 2.5-fold (0.39 log units) below what was measured, and the stated range covers the measured number.
By their numbers in this assay, from the lowest: compounds 3, 1 and 4 (each within the scatter of the next, the first and the last beyond it); then compound 2.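

In this assay, extending hydroxycarbamoyl to (hydroxycarbamoyl)methyl on this saturated chain carbon gives a 3.4-fold higher number from compound 3 to compound 4 (0.53 log units; beyond the scatter), the first step showing this change alone, and it lies beyond the scatter. On the same longer chain, hydrogen in place of 1H-benzimidazol-2-yl on an aromatic carbon gives a 2.9-fold lower number from compound 2 to compound 4 (0.47 log units; beyond the scatter), so the larger core carries the higher number here. Nothing available explains either step.

Still open, going by these compounds, is how a longer chain, such as 2-(hydroxycarbamoyl)ethyl, or a carboxylic acid in place of hydroxycarbamoyl would read at this place.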